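The source may hold more compounds than are shown below. What is called first, only, known or untested is meant among the compounds shown, and "the series" means these compounds.

In a functional assay on CCRF-CEM cells (Homo sapiens) for inhibition, read by MTT assay, with a stated time of 2 days, tested at 10 uM (on this read-out lower numbers stand for less inhibition and higher numbers for more inhibition at the one concentration tested (going by the name of the read-out)), compound 3 `COC(=O)c1cc(-n2cc(-c3ccc(OC)cc3)nn2)ccc1O` gives 16%, while compound 2 `COc1ccc(-c2cn(-c3ccc(O)c(C(=O)O)c3)nn2)cc1` gives 9%. The change between them, (hydrogen in place of methyl on an oxygen next to a carbonyl group), made a step of a number 7 percentage points lower from compound 3 to compound 2 (within the scatter). Compound 1 `COC(=O)c1cc(-n2cc(-c3cc(OC)cc(OC)c3)nn2)ccc1O` gives 3% in this assay; it differs from compound 3 in its core, and that difference between the two cores is not broken down here. Compound 4 `COc1cc(OC)cc(-c2cn(-c3ccc(O)c(C(=O)O)c3)nn2)c1` has not yet been measured in this assay. Among the measured compounds shown here, it differs from compound 1 by hydrogen in place of methyl on an oxygen next to a carbonyl group, the same change at the same place as the one between compound 3 and compound 2. Since that earlier step was a number 7 percentage points lower from compound 3 to compound 2 (within the scatter), a step of about the same size is expected here, a number 1 percentage points higher from compound 1 to compound 4 (within the scatter). The number has little room to fall because compound 1 already gives 3%. Compound 4 is therefore estimated at 4%, between -5% and 15%.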

Compound 4, a percentage reported as inhibition, at one concentration (the size of the read-out at that concentration, not a potency): 9%
For compound 4 the middle estimate is 5 percentage points below the measured one; low and high end bracket the measured number.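

In this assay, hydrogen in place of the methyl on the oxygen next to a carbonyl group, turning methoxycarbonyl into carboxy, made a step of a number 6 percentage points higher from compound 1 to compound 4 (within the scatter). Set beside the earlier step, this one does not differ from it: the same change on two cores in this assay, a number 7 percentage points lower (within the scatter) from compound 3 to compound 2 and a number 6 percentage points higher (within the scatter) from compound 1 to compound 4, 13 percentage points apart, within the scatter of two such steps. The change thus left the read-out within the scatter on both cores and shows no difference between them, but it establishes no direction for the change and says nothing about how it would behave on any other core.

From the compounds shown here alone, an amide or an ethyl ester in place of the methoxycarbonyl group remains open, as does an amine in place of a methoxy group. Potency also remains open, as each compound is shown at a single concentration.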